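Methylsulfanyl for methoxy across two related cores

The source may hold more compounds than are shown below. What is called first, only, known or untested is meant among the compounds shown, and "the series" means these compounds.

Working notes on four compounds, three of them measured in a functional assay on MCF7 cells (Homo sapiens) for cytotoxicity, read by MTT assay, with a stated time of 72 h; on this read-out higher numbers stand for weaker inhibition of growth and lower numbers for stronger inhibition of growth. Compound 1 `CSc1ccc(CNc2nc(SC)nc3ncccc23)cc1` gives 4370 nM in this assay. Compound 2 `COc1ccc(CNc2nc(SC)nc3ncccc23)cc1` reaches only a limit of the assay, > 100000 nM, in this assay. Compound 3 `COc1ccc(CNc2nc(SC)nc3ccccc23)cc1` gives 85100 nM in this assay, the higher of the two numbers, with compound 1 as its nearest neighbour. Compound 4 `CSc1ccc(CNc2nc(SC)nc3ccccc23)cc1` has not yet been measured.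

The change from compound 2 to compound 1 is methylsulfanyl in place of methoxy on an aromatic carbon and it produces an at least 22-fold lower number from compound 2 to compound 1 (1.35 log units; beyond the scatter). The size of that step is only a floor, because the limit of > 100000 nM in this assay, at which 1 of the 3 values shown sits, means the starting value is a limit rather than a number. Going by the values given here, the difference between the two cores, that of compound 2 and that of compound 3, is not broken down here; their values show only that compound 3 gives a number where compound 2 gives a limit.

The change from compound 3 to compound 4 is methylsulfanyl in place of methoxy on an aromatic carbon, the same change at the same place as from compound 2 to compound 1. On that basis a comparably large fall in the number is expected from compound 3 to compound 4, about a 17-fold lower number from compound 3 to compound 4 (1.23 log units; beyond the scatter), resting on the step of an at least 22-fold lower number from compound 2 to compound 1 (1.35 log units; beyond the scatter) seen with the other core. Among the compounds with values here, compound 4 is therefore estimated to give about 5000 nM in this assay, within a range of 1500 nM to 30000 nM because only the single measured pair an at least 22-fold lower number from compound 2 to compound 1 (1.35 log units; beyond the scatter) supports the transfer and the core differs.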

Compound 4, concentration for total growth inhibition: > 100000 nM
Compound 4 ended at the assay's limit; the forecaster's own chance of this, stated with the estimate: 5%; middle value at least 20-fold (1.30 log units) away from the limit.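

Compound 4 stands at > 100000 nM in this assay, and that value is a limit of the assay, not a number. Methylsulfanyl in place of methoxy on an aromatic carbon therefore does not carry over from one core to the other in this assay, the large fall on the core of compound 1 having no counterpart on the core of compound 3: the same change on two cores in this assay, an at least 22-fold lower number (1.35 log units; beyond the scatter) from compound 2 to compound 1 and an at least 1.1-fold higher number (0.07 log units; that floor lies within the scatter) from compound 3 to compound 4, at least 26-fold (1.42 log units) apart, beyond the scatter of two such steps. The new step, an at least 1.1-fold higher number from compound 3 to compound 4 (0.07 log units; that floor lies within the scatter), is only a floor, so neither its true size nor the reason the two cores part can be read from these pairs, and the reading is further restricted by how many values are not numbers: the limit of > 100000 nM in this assay, at which 2 of the 4 values shown sit.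

Left open is whether the fall seen on the core of compound 1 is particular to methylsulfanyl or also appears with an ethylsulfanyl group or a chlorine atom in the same place. As far as these compounds go, it is equally open whether a second pair on the core of compound 3, for instance with an amine in that place, would give values that are numbers rather than limits, and so allow the two cores to be compared directly.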